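The compounds below may be only part of what the source reports. "The series", "measured", "known", "first", "only" and "open" are said of these compounds alone.

Working notes on the series. Compound 1 `COc1ccc(-c2cc(/C=C/C(=O)c3ccc(N)cc3)[nH]n2)cc1` gives 96% in a functional assay on HCC 2998 cells (Homo sapiens) for cytotoxicity, read by sulforhodamine B assay, with a stated time of 48 h, tested at 0.01 uM; on this read-out higher numbers stand for a weaker effect at the one concentration tested and lower numbers for a stronger effect. Compound 2 `COc1cc(-c2cc(/C=C/C(=O)c3ccc(N)cc3)[nH]n2)cc(OC)c1OC` gives 108% in this assay. Of the two numbers in hand, that of compound 2 is the highest; the nearest is compound 1, lower by a gap beyond the scatter. Among the compounds with values here, no pair of measured compounds that differ in one place is available, so no step has been followed through the measured set; the two values only show that both compounds sit at the weak end of the read-out at the single concentration tested.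

Compound 3 `COc1cc(-c2cc(/C=C/C(=O)c3ccc(Cl)c(Cl)c3)[nH]n2)cc(OC)c1OC` differs from compound 2 by 3,4-dichlorophenyl in place of 4-aminophenyl on a carbonyl carbon. Within the data shown here, with no measured step to anchor the change, the expectation rests on the values of compound 2 and compound 1 alone. The step from compound 2 to compound 3 in this assay is expected to be a number 7 percentage points lower from compound 2 to compound 3 (within the scatter), that is, none beyond the scatter. Compound 3 is therefore estimated at 101% in this assay, with a range from 86% to 116%.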

Compound 3, a percentage reported as activity, at one concentration (the size of the read-out at that concentration, not a potency): 96%
Compound 3: the middle estimate sits 5 percentage points above what was measured; the measured number falls inside the stated range.
By their numbers in this assay, from the lowest: compounds 1 and 3 (each within the scatter of the next); then compound 2.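

In this assay, within the data shown here, 3,4-dichlorophenyl in place of 4-aminophenyl on a carbonyl carbon gives a number 12 percentage points lower from compound 2 to compound 3 (beyond the scatter), the first step that can be followed between compounds differing in one place. The read-out therefore responds to the aryl group carried at this carbonyl carbon, although compound 3 at 96% remains at the weak end of the read-out at the single concentration tested, and the exchange removes the amine and brings in two chlorines in one step, so the shift cannot be assigned to either change alone. No measurement bearing on this step is available to explain it.

Going by these compounds, whether a plain phenyl or a phenyl bearing a single chlorine on the same carbonyl carbon would read like compound 2 or like compound 3 remains open, as does the separate contribution of the amine and the chlorines. Also open, on these data alone, is whether the same exchange gives a step of similar size on the core of compound 1, and whether any group here moves the read-out clearly away from its weak end.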